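Chloro Added on the Phenyl Ring: Compound 2 to Compound 3

A few compounds are considered here, and "the series" means these few. Any claim that something is new, unique, unknown or untested is made for them only; others in the source may bear on it.

Measured so far:
compound 1, `CO/C(=C\c1ccccc1)C(=O)Nc1ccc(Cl)cc1`, 17000 nM in a functional assay on cells (Splenocyte, Mus musculus, strain BALB/c) for inhibition, read by MTT assay, with a stated time of 48 h; on this read-out higher numbers stand for weaker inhibition and lower numbers for stronger inhibition
compound 2, `CO/C(=C\c1ccccc1)C(=O)Nc1ccc(C)cc1`, 16600 nM in this assay

Among the measured compounds shown here, compound 2 is one of only two compounds measured, and its number and that of compound 1 lie within the scatter of each other: the step is a 1.0-fold lower number from compound 1 to compound 2 (0.01 log units; within the scatter). Nothing in these two values separates the compounds, so compound 2 has no distinct standing beyond being one of a pair that reads alike.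

Compound 3, `CO/C(=C\c1ccc(Cl)cc1)C(=O)Nc1ccc(C)cc1`, differs from compound 2 by chloro in place of hydrogen on an aromatic carbon. For the measured compounds named here, the only measured step, from compound 1 to compound 2, exchanges substituents at a different place and stays within the scatter, so it bears on the present change only indirectly. Going by the values given here, there is no measured pair in which chloro enters the phenyl ring, and no measured step here exceeds the scatter. On this basis the step from compound 2 to compound 3 is expected to be a 1.0-fold lower number from compound 2 to compound 3 (0.02 log units; within the scatter), that is, none beyond the scatter. Compound 3 is therefore estimated at 16000 nM in this assay, with a range from 6000 nM to 45000 nM.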

Compound 3, half-maximal inhibitory concentration: 12700 nM
Compound 3: the middle estimate sits 1.3-fold (0.10 log units) above what was measured; low and high end bracket the measured number.
By their numbers in this assay, from the lowest: compounds 3, 2 and 1 (each within the scatter of the next).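

Chloro in place of hydrogen, the change from phenyl to 4-chlorophenyl, gives a 1.3-fold lower number from compound 2 to compound 3 (0.12 log units; within the scatter) in this assay, which is the first reading of a substituent on this ring, at the place para to a large group. At this place, chloro and hydrogen cannot be told apart by this read-out, so the ring carries the added heavy atom with no change beyond the scatter. The earlier step, a 1.0-fold lower number from compound 1 to compound 2 (0.01 log units; within the scatter), lies on the other aromatic ring and is also within the scatter, so neither single change shown so far separates two compounds, and no evidence bears on this result.

Going by these compounds, it remains open whether any group at this place moves the number beyond the scatter, for example an amine, a carboxylic acid or a methoxy group in place of the chloro of compound 3. Also open, on these data alone, is whether the series responds to a change away from the two aromatic rings, such as an ethoxy group or a longer chain in place of the methoxy group of the shared core.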